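This account rests on a few compounds, and the source may have more. Where it says the series, first, only, none or still open, it means among the compounds named here.

In a physicochemical assay for solubility (a lower number here means a less soluble compound, a higher number a more soluble compound), compound 1 `O=C(O)c1ccc(C(=O)/C(=C\c2ccc(F)c([N+](=O)[O-])c2)S(=O)(=O)Cc2ccc(Br)cc2)cc1` reads < 1000 ug/mL, which is a limit of the assay and not a number. Compound 2 `O=C(O)c1ccc(C(=O)/C(=C\c2ccc(F)c([N+](=O)[O-])c2)SCc2ccc(F)cc2)cc1` reads < 1000 ug/mL, again a limit. Compound 3 `O=C(O)c1ccc(C(=O)/C(=C\c2ccc(F)c([N+](=O)[O-])c2)SCc2ccccc2)cc1` reads < 1000 ug/mL, also a limit, so it has no exact place on the scale. All the evidence so far is the limit of < 1000 ug/mL in this assay, at which 3 of the 3 values shown sit.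

Compound 4 `O=C(O)c1ccc(C(=O)/C(=C\c2ccc(F)c([N+](=O)[O-])c2)SCc2ccccc2Cl)cc1` differs from compound 3 by a single change: chloro in place of hydrogen on an aromatic carbon. This turns benzylsulfanyl into (2-chlorobenzyl)sulfanyl. The closest measured change, also on an aromatic carbon, is a step that the two limits leave unreadable from compound 2 to compound 3. The two larger swaps are a step that the two limits leave unreadable from compound 1 to compound 2 and a step that the two limits leave unreadable from compound 1 to compound 3. None of these gives a size or a direction to carry over, so no step beyond the scatter is expected in this assay. The expected step, estimated with little confidence, is a step that the limit leaves unreadable from compound 3 to compound 4. Compound 4 is estimated at about 400 ug/mL, with an expected range from 100 ug/mL to 1000 ug/mL. A report as a limit once more is the likeliest outcome.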

Compound 4, solubility: < 1000 ug/mL
Compound 4 ended at the assay's limit; the forecaster's own chance of this, stated with the estimate: 85%; the middle value does not contradict the limit.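

Going by these compounds alone, compound 4 gives only a limit in this assay, so no step to it from compound 1, compound 2 or compound 3 can be read. The compounds shown leave open whether any of these changes shifts solubility at all, with everything so far resting on one reading: the limit of < 1000 ug/mL in this assay, at which 4 of the 4 values shown sit.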